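The source may hold more compounds than are shown below. What is called first, only, known or untested is meant among the compounds shown, and "the series" means these compounds.

Measured compounds:
- compound 1 `CC1=C(C)C(N)=NCC1`, giving 310 nM in an assay on A549 cells with Nitric oxide synthase, inducible (Homo sapiens) as the target; a higher number here means a weaker inhibitor, a lower number a stronger inhibitor
- compound 2 `CCCC1CC(C)=CC(N)=N1`, giving 60 nM in this assay

For the measured compounds named here, of the two numbers in this assay, compound 2 holds the lower one; the only neighbour, compound 1, sits at a value higher by more than the usual scatter of repeat measurements, so the difference between them counts as real. Compound 3 `C=CCC1CC(C)=CC(N)=N1` is not yet measured in this assay. It differs from compound 2 in one place: vinyl in place of ethyl on a saturated chain carbon bound to a saturated ring carbon. Going by the values given here, no pair among the measured compounds shows this kind of exchange, so no measured step can be carried over. The change keeps the count of heavy atoms and adds only one double bond outside aromatic rings. The expected step is therefore small, a 1.2-fold higher number from compound 2 to compound 3 (0.07 log units; within the scatter), with no direction claimed beyond the scatter. Compound 3 is expected to give about 70 nM in this assay, within a range from 30 nM to 160 nM.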

Compound 3, half-maximal inhibitory concentration: 50 nM
The estimate for compound 3 lay 1.4-fold (0.15 log units) above the measured number, and the stated range covers the measured number.
By their numbers in this assay, from the lowest: compounds 3 and 2 (each within the scatter of the next); then compound 1.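

For the compounds shown here, the exchange of vinyl for ethyl on a saturated chain carbon bound to a saturated ring carbon gives the first single-place step: a 1.2-fold lower number from compound 2 to compound 3 (0.08 log units; within the scatter) in this assay. The one added double bond outside aromatic rings thus leaves the number within the scatter, and propyl and allyl, the same difference cut one bond further out, are not told apart at this position. No measured evidence bears on this result.

The compounds shown leave open how far this position accepts other groups, such as a longer chain like pentyl, a terminal alkyne, a phenyl ring or a primary amine. Going by these compounds alone, with only this one pair, they also leave open whether the same exchange would read alike on other members.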